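This account rests on a few compounds, and the source may have more. Where it says the series, first, only, none or still open, it means among the compounds named here.

Of the compounds shown here, three with a shared core have been measured in an assay on blood for inhibition of Polyunsaturated fatty acid 5-lipoxygenase (Homo sapiens), tested at 10 uM; a lower number here means a weaker effect, a higher number a stronger effect of the compound at the concentration tested. Compound 1 `O=C1OC(c2ccc(OCc3ccccc3)cc2)C(c2ccc(F)cc2)=C1O` gives 0% in this assay. Compound 2 `O=C1OC(c2ccc(O)c(O)c2)C(c2ccc(O)cc2)=C1O` gives 35.4%, and compound 3 `O=C1OC(c2ccc(O)cc2)C(c2ccc(O)cc2)=C1O` gives 0%. Compound 3 stands level with compound 1 at the digits shown, and together they are the lowest of the three numbers; compound 2 lies higher, and the one measured step, a number 35.4 percentage points lower from compound 2 to compound 3 (beyond the scatter), shows how much was lost there by swapping hydroxy for hydrogen on an aromatic carbon.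

Compound 4 `O=C1OC(c2ccc(O)cc2)C(c2ccc(F)cc2)=C1O` has not been measured. It differs from compound 3 in one place: fluoro in place of hydroxy on an aromatic carbon. For the measured compounds named here, no measured step describes a swap of hydroxy for fluoro, and the only step recorded concerns a different ring. What the numbers do show is that compound 3 and compound 1, which carries fluoro in the same position, both sit at the floor of this assay. On that basis compound 4 is expected to stay where compound 3 is, with an estimated step of no change at the digits printed from compound 3 to compound 4 (within the scatter), that is, none beyond the scatter. The estimate for compound 4 is 0%, expected to fall between 0% and 10%.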

Compound 4, a percentage reported as activity, at one concentration (the size of the read-out at that concentration, not a potency): 0%
Compound 4: middle estimate and measured number agree at the digits printed, and the stated range covers the measured number.
By their numbers in this assay, from the lowest: compounds 1, 3 and 4 (each within the scatter of the next); then compound 2.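

In this assay the swap of 4-hydroxyphenyl for 4-fluorophenyl gives no change at the digits printed from compound 3 to compound 4 (within the scatter), so on this ring, in a compound already at the bottom of the range, a hydroxy is not needed to keep the number where it stands. Replacing benzyl with hydrogen on the oxygen of the other ring gives no change at the digits printed from compound 1 to compound 4 (within the scatter), which means that neither change lifts the read-out above the level of these inactive compounds. No data are available to explain these results.

As far as these compounds go, with all three compounds at the same bottom value, it remains open whether fluoro in place of hydroxy would matter in the more active compound 2. Also open, from the compounds shown here alone, is whether an amine or a carboxylic acid at this place on the ring would raise the number.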